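The compounds below may be only part of what the source reports. "The series", "measured", "known", "first", "only" and "open" are said of these compounds alone.

Measured compounds:

Compound 1, `COc1ccc(-c2nnc(N3CCN(C(=O)CN4CCN(c5ccccc5)CC4)CC3)nc2-c2ccc(OC)cc2)cc1`: in a functional assay on MCF7 cells (Homo sapiens) for cytotoxicity, read by MTT assay, with a stated time of 24 h (on this read-out lower numbers stand for stronger inhibition and higher numbers for weaker inhibition), compound 1 gives > 863000 nM, a limit of the assay and not a number.
Compound 2, `COc1ccc(-c2nnc(N3CCN(C(=O)CN4CCN(c5cccc(OC)c5)CC4)CC3)nc2-c2ccc(OC)cc2)cc1`: in this assay compound 2 gives > 821000 nM, again a limit.
Compound 3, `O=C(CN1CCN(c2ccccc2)CC1)N1CCN(c2nnc(-c3ccc(Cl)cc3)c(-c3ccc(Cl)cc3)n2)CC1`: in this assay compound 3 gives > 850000 nM, again a limit.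

The change from compound 1 to compound 2 is methoxy in place of hydrogen on an aromatic carbon. The step that the two limits leave unreadable from compound 1 to compound 2 cannot be read, since both ends sit at limits, as the limit of > 863000 nM in this assay, at which 1 of the 3 values shown sits, and the limit of > 821000 nM in this assay, at which 1 of the 3 values shown sits, show.

Compound 4, `COc1ccccc1N1CCN(CC(=O)N2CCN(c3nnc(-c4ccc(Cl)cc4)c(-c4ccc(Cl)cc4)n3)CC2)CC1`, is not yet measured. It differs from compound 3 by methoxy in place of hydrogen on an aromatic carbon, the same kind of change as from compound 1 to compound 2, though the place differs: meta to a large group in compound 2, ortho to a large group in compound 4. The difference between the core of compound 1 and the core of compound 3 is not broken down here.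

With every value shown sitting at a limit, the limit of > 850000 nM in this assay, at which 1 of the 3 values shown sits, included, compound 4 is expected to give 900000 nM in this assay, between 200000 nM and 3000000 nM. The step that the limit leaves unreadable from compound 3 to compound 4 is thus expected to be unreadable, most likely another limit.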

Compound 4, half-maximal inhibitory concentration: 330000 nM
The estimate for compound 4 lay 2.7-fold (0.44 log units) above the measured number, within the range that was stated.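

On the core of compound 3, methoxy in place of hydrogen, ortho to a large group on the phenyl ring, gives an at least 2.5-fold lower number from compound 3 to compound 4 (0.41 log units; beyond the scatter) in this assay, so on this core the change does lower the number. The same kind of change on the core of compound 1 cannot be read, since both ends of that step sit at limits and the methoxy stands at a different place on the ring, so these compounds do not show that the result carries from one core to the other, nor that it fails to. The value of compound 3 is a limit of the assay and not a number, so the full size of the new step stays unread: the limit of > 850000 nM in this assay, at which 1 of the 4 values shown sits.

Still open, from the compounds shown here alone, is whether methoxy ortho to a large group lowers the number on the core of compound 1, and whether methoxy at the other place does so on the core of compound 3. Also open, going by these compounds, is how an amine or a carboxylic acid on the same phenyl ring, or a longer chain in place of the methoxy, would read in this assay.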